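A few compounds are considered here, and "the series" means these few. Any claim that something is new, unique, unknown or untested is made for them only; others in the source may bear on it.

Measured in a functional assay on SH-SY5Y cells (Homo sapiens) for cytotoxicity, read by MTT assay, with a stated time of 72 h; a lower number here means a stronger inhibitor, a higher number a weaker inhibitor:
- compound 1 `O=C1c2c[n+]([O-])c3ccccc3c2C(=O)c2c1c1ccccc1n2CCN1CCCC1`: 520 nM
- compound 2 `O=C1c2c[n+]([O-])c3ccccc3c2C(=O)c2c1c1ccccc1n2CCN1CCCCC1`: 1860 nM

In this assay, going by the values given here, compound 2 at 1860 nM has the higher of the two numbers, and compound 1 is its only neighbour. Compound 3 `CN(C)CCCCn1c2c(c3ccccc31)C(=O)c1c[n+]([O-])c3ccccc3c1C2=O` carries 2-(dimethylamino)ethyl in place of piperidin-1-yl on a saturated chain carbon, two bonds along the chain from an aromatic nitrogen. Among the compounds with values here, only one measured step bears on this change: a 3.6-fold higher number from compound 1 to compound 2 (0.55 log units; beyond the scatter), at the same place and modest in size. That step swaps one ring for another, whereas compound 3 has no ring there, and no open-chain amine has been measured, so the comparison is loose. A step of similar or smaller size is therefore expected, leaning slightly towards a lower number, since compound 2 stands at the top of the pair. The expected step is a 1.9-fold lower number from compound 2 to compound 3 (0.27 log units; within the scatter). The estimated value for compound 3 is 1000 nM, with an expected range of 300 nM to 3500 nM.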

Compound 3, half-maximal inhibitory concentration: 250 nM
Compound 3: middle estimate off by 4.0-fold (0.60 log units), on the high side; the measured number lies below the stated range.
By their numbers in this assay, from the lowest: compound 3; then compound 1; then compound 2.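

In this assay, replacing the ring amine with the open-chain 2-(dimethylamino)ethyl gives a 7.4-fold lower number from compound 2 to compound 3 (0.87 log units; beyond the scatter), and against the smaller ring it gives a 2.1-fold lower number from compound 1 to compound 3 (0.32 log units; beyond the scatter), so compound 3 has the lowest number of the three. This position therefore tolerates more than a swap of one ring for another: a ring is not needed here for a number in this range, and the open-chain group goes beyond both ring amines rather than falling between them. No measurement on the compounds shown accounts for this difference.

The step from compound 2 to compound 3 changes ring to open chain and chain length together, as 2-(piperidin-1-yl)ethyl to 4-(dimethylamino)butyl, and the compounds shown cannot separate the two changes. A 4-(piperidin-1-yl)butyl chain, or a 2-(dimethylamino)ethyl chain on the aromatic nitrogen, would pull them apart.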